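A few compounds are considered here, and "the series" means these few. Any claim that something is new, unique, unknown or untested is made for them only; others in the source may bear on it.

Measured compounds:

Compound 1, `NC(=S)N1CCc2c(OCCCCCOc3ccc(Cl)cc3)cccc21`. In an ADME assay on Huh-7 cells (Homo sapiens) for cytotoxicity (on this read-out lower numbers stand for higher toxicity in this test and higher numbers for lower toxicity in this test), compound 1 gives > 50000 nM, which is a limit of the assay and not a number.

Compound 2, `O=C(NC(=S)N1CCc2c(OCCCCCOc3ccc(Cl)cc3)cccc21)Oc1ccccc1`. In this assay compound 2 gives > 50000 nM, again a limit of the assay.

Compound 3, `N#Cc1ccc(C(=O)NC(=S)N2CCc3c(OCCCCCOc4ccc(Cl)cc4)cccc32)cc1`. In this assay compound 3 gives > 50000 nM, also a limit of the assay.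

Compound 3 therefore stands where every value in this set stands: the limit of > 50000 nM in this assay, at which 3 of the 3 values shown sit. The three measured steps cannot be sized, since a step that the two limits leave unreadable from compound 1 to compound 2, a step that the two limits leave unreadable from compound 1 to compound 3 and a step that the two limits leave unreadable from compound 2 to compound 3 all run between two limits.

Compound 4, `Cc1ccc(C(=O)NC(=S)N2CCc3c(OCCCCCOc4ccc(Cl)cc4)cccc32)cc1`, differs from compound 3 by methyl in place of cyano on an aromatic carbon. For the measured compounds named here, the only steps that bear on this change, those from compound 1 and compound 2 to compound 3, are unreadable in this assay, so nothing in the set points to a shift in either direction. The step of a number no higher from compound 3 to compound 4 (the limit leaves the size open) is expected to be none beyond the scatter. Compound 4 is expected to give 50000 nM in this assay, with a range from 25000 nM to 100000 nM, most likely reported once more as a limit.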

Compound 4, half-maximal cytotoxic concentration: > 50000 nM
Compound 4 ended at the assay's limit; the forecaster's own chance of this, stated with the estimate: 85%; the middle value lies on the limit itself.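

In this assay compound 4 gives > 50000 nM, a limit of the assay and not a number. Its steps from compound 1, compound 2 and compound 3 cannot be read. What stays open is the concentration at which any of these compounds becomes cytotoxic, with all values alike: the limit of > 50000 nM in this assay, at which 4 of the 4 values shown sit.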